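Amino for methyl on the pyridyl arm of compound 2

A few compounds are considered here, and "the series" means these few. Any claim that something is new, unique, unknown or untested is made for them only; others in the source may bear on it.

In a functional assay for antagonist activity at metabotropic glutamate receptor 5 (Rattus norvegicus) (a lower number here means a stronger inhibitor, a higher number a weaker inhibitor), compound 1 `Cc1cnccc1-c1cc(F)cc(-n2nnc(-c3ccccn3)n2)c1` gives 63 nM, whereas compound 2 `Cc1cncc(-c2cc(F)cc(-n3nnc(-c4ccccn4)n3)c2)c1` gives 499 nM, the higher of the two numbers, reached by a 7.9-fold higher number from compound 1 to compound 2 (0.90 log units; beyond the scatter). Compound 3 `Nc1ccncc1-c1cc(F)cc(-n2nnc(-c3ccccn3)n2)c1` differs from compound 2 by 4-aminopyridin-3-yl in place of 5-methylpyridin-3-yl on an aromatic carbon. Among the measured compounds shown here, no measured step covers an amino group in this position; the single step in this assay shows only that rearranging the pyridyl arm shifts the number modestly. The author therefore expects a change of about a 1.7-fold lower number from compound 2 to compound 3 (0.22 log units; within the scatter), with wide uncertainty. Compound 3 is estimated at 300 nM, within 60 nM to 1500 nM.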

Compound 3, half-maximal inhibitory concentration: 108 nM
The estimate for compound 3 lay 2.8-fold (0.44 log units) above the measured number; the range from low to high includes it.
By their numbers in this assay, from the lowest: compounds 1 and 3 (each within the scatter of the next); then compound 2.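

In this assay, 4-aminopyridin-3-yl in place of 5-methylpyridin-3-yl on this aromatic carbon gives a 4.6-fold lower number from compound 2 to compound 3 (0.66 log units; beyond the scatter), so a pyridin-3-yl arm can recover most of what the earlier step lost. Set against the 3-methylpyridin-4-yl arm, the change gives a 1.7-fold higher number from compound 1 to compound 3 (0.23 log units; within the scatter), so these two arms cannot be told apart in this assay. No evidence is available to explain these steps. The compounds shown leave open whether the amino group itself or the rest of the arm carries the step, and how a methylamino or methoxy group on the same arm would read.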